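The compounds below may be only part of what the source reports. "The series", "measured", "known", "first", "only" and "open" are said of these compounds alone.

Measured so far in a functional assay on KB 3-1 cells (Homo sapiens) for cytotoxicity, read by MTT assay, with a stated time of 72 h; a lower number here means a stronger inhibitor, a higher number a weaker inhibitor:

- Compound 1 `O=C1Nc2ccccc2/C1=N/NC(=S)Nc1ccccc1`: 3530 nM
- Compound 2 `CC(C)c1ccc(NC(=S)N/N=C2\C(=O)Nc3ccccc32)cc1`: 9110 nM

Of these two, compound 2 has the higher number at 9110 nM, which makes it the weaker inhibitor. Compound 3 `CC(C)(C)c1ccc(NC(=S)N/N=C2\C(=O)Nc3ccccc32)cc1` has not been measured yet. Its difference from compound 2 is small: methyl in place of hydrogen on a saturated chain carbon bound to an aromatic carbon and two saturated chain carbons. Put simply, a methyl replaces a hydrogen on a saturated chain carbon bound to an aromatic carbon and two saturated chain carbons, so isopropyl becomes tert-butyl.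

Among the compounds with values here, only one measured step bears on this change. Putting isopropyl in place of hydrogen on an aromatic carbon gave a 2.6-fold higher number from compound 1 to compound 2 (0.41 log units; beyond the scatter), a modest step towards weaker inhibition. The new change enlarges that same isopropyl group by a single methyl, so a further rise in this assay is expected, though a smaller one, and it may not exceed the scatter. A single step is thin evidence, so the range stays wide. The estimate means an expected 1.2-fold higher number from compound 2 to compound 3 (0.08 log units; within the scatter). For compound 3 the estimated value is 11000 nM, with an expected range from 5000 nM to 24000 nM.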

Compound 3, half-maximal inhibitory concentration: 8130 nM
Compound 3: middle estimate off by 1.4-fold (0.13 log units), on the high side; the range from low to high includes it.
By their numbers in this assay, from the lowest: compound 1; then compounds 3 and 2 (each within the scatter of the next).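

Enlarging isopropyl to tert-butyl gives a 1.1-fold lower number from compound 2 to compound 3 (0.05 log units; within the scatter) in this assay, so the added methyl makes no readable difference and compounds 2 and 3 cannot be ranked against each other. The earlier compounds showed only that one branched group on this aromatic carbon moved the number away from hydrogen; now tert-butyl in place of that hydrogen gives a 2.3-fold higher number from compound 1 to compound 3 (0.36 log units; beyond the scatter) and, like a 2.6-fold higher number from compound 1 to compound 2 (0.41 log units; beyond the scatter), that step lies beyond the scatter, so among these three compounds both branched groups stand apart from hydrogen. The step from hydrogen to a branched group is therefore readable here, while the step from one branched group to the next is not, and no other kind of measurement is available to account for this.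

These compounds leave open whether a smaller group, such as a single methyl, would already give a step of this kind from compound 1. From the compounds shown here alone, it is also open whether a group of a different type on the same aromatic carbon, such as an amine or a carboxylic acid, would bring the number level with compound 1 or take it lower.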